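The compounds below may be only part of what the source reports. "The series", "measured", "known", "first", "only" and "open" are said of these compounds alone.

Measured in a physicochemical assay for solubility, with a stated time of 3 days, at pH 2; on this read-out lower numbers stand for lower solubility and higher numbers for higher solubility:
- Compound 1 `NC(=O)c1ccc2[nH]c(-c3ccc(OC4CCCNC4)cc3)nc2c1`: > 400000 nM, a limit.
- Compound 2 `NC(=O)c1ccc2[nH]c(-c3ccc(OCC4CCNCC4)cc3)nc2c1`: > 400000 nM, a limit.
- Compound 3 `NC(=O)c1ccc2[nH]c(-c3ccc(OCCC4CCCCN4Cc4ccc(Cl)cc4)cc3)nc2c1`: > 400000 nM, a limit.

Compound 3 has no number of its own and shares its place with the other two compounds, as the series shows (the limit of > 400000 nM in this assay, at which 3 of the 3 values shown sit).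

The next comparison is with compound 4 `CC(=O)N1CCCCC1CCOc1ccc(-c2nc3cc(C(N)=O)ccc3[nH]2)cc1`, which has acetyl in place of 4-chlorobenzyl on an amine nitrogen in a ring.

Going by the values given here, the one measured step, a step that the two limits leave unreadable from compound 1 to compound 2, gives no size and concerns a different change. Among the compounds with values here, no measured step covers this replacement. The expectation rests on (the limit of > 400000 nM in this assay, at which 3 of the 3 values shown sit), which holds for compound 3 with 4-chlorobenzyl and for compounds 1 and 2 without it.

The expected change in this assay is a number no higher from compound 3 to compound 4 (the limit leaves the size open), with no shift beyond the scatter anticipated and another reading at the limit likely. For compound 4 the estimated value is 400000 nM, with an expected range from 180000 nM to 500000 nM.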

Compound 4, solubility: > 400000 nM
Compound 4: only a limit was reported; the forecaster's own chance of this, stated with the estimate: 75%; the middle value lies on the limit itself.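

In this assay compound 4 gives > 400000 nM, which is a limit. The steps from compound 2 and compound 3 to compound 4 therefore cannot be read. The compounds shown leave open how compounds 1 to 4 actually rank, since every reading remains a limit: the limit of > 400000 nM in this assay, at which 4 of the 4 values shown sit.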